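The source may report more compounds than this note shows. Statements on the series, on what has been measured and on what is new or still open speak of the compounds shown alone.

Measured compounds:
compound 1, `CCCN(CCC)c1cccc2nc(Nc3c(OC)cc(OC)cc3OC)c(C)cc12` — in an assay on HEK293 cells for displacement of a labelled ligand from corticotropin-releasing factor receptor 1 (Homo sapiens), read by scintillation proximity assay, with a stated time of 2 h (a lower number here means a stronger inhibitor, a higher number a weaker inhibitor), compound 1 gives > 1000 nM, which is a limit of the assay and not a number.
compound 2, `COCc1cc(OC)c(Oc2nc3cccc(N(CC4CCOCC4)CC4CC4)c3cc2C)c(OC)c1` — in this assay compound 2 gives 762 nM.

For the measured compounds named here, compound 2 holds the only actual number in this assay among the two measured compounds; the other entry sits at the limit (the limit of > 1000 nM in this assay, at which 1 of the 2 values shown sits), so no step between compound 1 and compound 2 can be stated. Compound 3, `COCc1cc(OC)c(Oc2nc3cccc(N(CC4CC4)C4CCOCC4)c3cc2C)c(OC)c1`, differs from compound 2 in one place: oxan-4-yl in place of (oxan-4-yl)methyl on a nitrogen on an aromatic ring. Going by the values given here, no measured pair shows a change of this kind, so the direction of the step is open. A step of a 1.1-fold higher number from compound 2 to compound 3 (0.05 log units; within the scatter) is expected, none beyond the scatter. In this assay compound 3 is expected at 850 nM, with a range from 300 nM to 2500 nM.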

Compound 3, half-maximal inhibitory concentration: 157 nM
The estimate for compound 3 lay 5.4-fold (0.73 log units) above the measured number, outside the stated range (below it).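

In this assay, the substituent on a nitrogen on an aromatic ring proves sensitive to how the ring is attached: oxan-4-yl in place of (oxan-4-yl)methyl gives a 4.9-fold lower number from compound 2 to compound 3 (0.69 log units; beyond the scatter). The six-membered non-aromatic ring with 1 hetero atom stays in both compounds, as does the cyclopropylmethyl on the same nitrogen, so the change at this place is confined to the attachment of that ring. Nothing in the data at hand accounts for the size or direction of this step.

As far as these compounds go, whether the direction of the step carries over to other rings, such as cyclohexyl or piperidin-4-yl in place of oxan-4-yl, remains open. Also open, from the compounds shown here alone, is how a longer chain, such as 2-(oxan-4-yl)ethyl, would read at this nitrogen, and whether the step holds with another group in place of cyclopropylmethyl.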